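The compounds below may be only part of what the source reports. "The series", "measured", "known", "first", "only" and "open" are said of these compounds alone.

Compound 1 `O=S(=O)(NCCNc1nccc(-c2c(-c3cccc(F)c3)nc3sccn23)n1)c1cccc(F)c1` and compound 2 `O=S(=O)(NCCCNc1nccc(-c2c(-c3cccc(F)c3)nc3sccn23)n1)c1ccccc1` share one core and differ in the chain between the core and the terminal group and in that terminal group itself. In a functional assay on A-375 cells (Homo sapiens) for cytotoxicity, read by MTT assay (on this read-out higher numbers stand for weaker inhibition and lower numbers for stronger inhibition), compound 1 gives 14900 nM, and in this assay compound 2 gives 6600 nM. Within the data shown here, the only measured step, a 2.3-fold lower number from compound 1 to compound 2 (0.35 log units; beyond the scatter), leaves compound 2 with the lower of the two numbers. Compound 3 `O=C(NCCCNc1nccc(-c2c(-c3cccc(F)c3)nc3sccn23)n1)c1ccc(F)cc1` is not yet measured; it differs from compound 2 by (4-fluorophenyl)carbonyl in place of phenylsulfonyl on an amine nitrogen. Among the measured compounds shown here, no measured step exchanges a sulfonyl for a carbonyl at this position; the one known step touches the aryl group and the chain length and was modest. On that basis a step of at most modest size is expected, in no firm direction. Compound 3 is therefore expected to give about 7000 nM, within 2500 nM to 20000 nM. The step of a 1.1-fold higher number from compound 2 to compound 3 (0.03 log units; within the scatter) is thus estimated to stay near the scatter.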

Compound 3, half-maximal inhibitory concentration: 14900 nM
The estimate for compound 3 lay 2.1-fold (0.33 log units) below the measured number, within the range that was stated.
By their numbers in this assay, from the lowest: compound 2; then compounds 1 and 3 (each within the scatter of the next).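

In this assay, replacing phenylsulfonyl with (4-fluorophenyl)carbonyl on the amine nitrogen, with the chain unchanged, gives a 2.3-fold higher number from compound 2 to compound 3 (0.35 log units; beyond the scatter) and so shows that this position responds to this change alone, with inhibition weaker on the carbonyl side. The broader exchange of ((3-fluorophenyl)sulfonyl)amino for (((4-fluorophenyl)carbonyl)amino)methyl gives no change at the digits printed from compound 1 to compound 3 (within the scatter) even though the chain and the terminal group both differ, so a difference in both places need not appear in this read-out. Nothing measured here explains these numbers.

Since the carbonyl and the fluorine enter together, the compounds shown do not separate their contributions, and a plain benzoyl or a (4-fluorophenyl)sulfonyl group on the same nitrogen would address that. As far as these compounds go, how a longer chain or a terminal amine would behave at this position also remains open.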